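The compounds below may be only part of what the source reports. "The series", "measured", "known", "first", "only" and "open" are said of these compounds alone.

Three esters built on one shared core have been measured in an ADME assay on HepG2 2.2.15 cells (Homo sapiens) for cytotoxicity; a higher number here means that more compound is tolerated, a lower number that less compound is tolerated. Compound 1 `CC(=O)OCCc1c(-c2ccccc2Cl)c2cc(Cl)ccc2[nH]c1=O` gives 27000 nM, compound 2 `N#CCC(=O)OCCc1c(-c2ccccc2Cl)c2cc(Cl)ccc2[nH]c1=O` gives 100000 nM and compound 3 `O=C(OCCc1c(-c2ccccc2Cl)c2cc(Cl)ccc2[nH]c1=O)c1ccc([N+](=O)[O-])cc1` gives 1600000 nM, the highest of the three numbers. The two lower compounds are themselves separated by a modest step, a 3.7-fold higher number from compound 1 to compound 2 (0.57 log units; beyond the scatter), whereas compound 3 stands apart from both: the data show a 59-fold higher number from compound 1 to compound 3 (1.77 log units; beyond the scatter) and a 16-fold higher number from compound 2 to compound 3 (1.20 log units; beyond the scatter), each of them large.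

Compound 4 `O=C(OCCc1c(-c2ccccc2Cl)c2cc(Cl)ccc2[nH]c1=O)c1cccs1` keeps the core and the ester and differs from compound 3 in one place, with thiophen-2-yl in place of 4-nitrophenyl on a carbonyl carbon. The two large steps bear most directly on this change, as they are the ones in which 4-nitrophenyl enters, and here that group leaves. Among the measured compounds shown here, no measured compound carries thiophen-2-yl, so the size of the step rests on limited evidence. Compound 4 is expected to fall back towards the two lower compounds, though probably not all the way to the lowest.

The estimated change is a 13-fold lower number from compound 3 to compound 4 (1.12 log units; beyond the scatter), a large step to a lower number. In this assay, compound 4 is estimated at 120000 nM, with an expected range from 30000 nM to 600000 nM.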

Compound 4, half-maximal cytotoxic concentration: > 1700000 nM
Compound 4 gave a limit, no number; the forecaster's own chance of this, stated with the estimate: 10%; middle value at least 14-fold (1.15 log units) from the limit.
By their numbers in this assay, from the lowest: compound 1; then compound 2; then compound 3. At a limit, above all of these: compound 4.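

In this assay compound 4 gives > 1700000 nM, which is a limit of the assay and not a number. The earlier compounds shown here linked the high end of this position to 4-nitrophenyl alone, but thiophen-2-yl on the same carbonyl carbon shows that this end does not depend on that group or on its nitrogen and oxygen atoms, with an at least 17-fold higher number from compound 2 to compound 4 (1.23 log units; beyond the scatter) and an at least 62-fold higher number from compound 1 to compound 4 (1.79 log units; beyond the scatter), both large steps that keep compound 2 and compound 1 well apart from compound 4. The remaining step, an at least 1.0-fold higher number from compound 3 to compound 4 (0.02 log units; that floor lies within the scatter), has a floor within the scatter, so compound 3 and compound 4 cannot be put in order, because the reading of compound 4 stops at a limit: the limit of > 1700000 nM in this assay, at which 1 of the 4 values shown sits.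

The compounds shown leave open how far compound 4 lies past its limit, and whether the two aromatic rings, one six-membered and one five-membered, share the high end as rings or each for a reason of its own. A plain phenyl, a saturated ring such as cyclohexyl or a longer alkyl chain on the carbonyl carbon would test this, as would an amide in place of the ester.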